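The source may hold more compounds than are shown below. What is called first, only, known or untested is meant among the compounds shown, and "the series" means these compounds.

Working notes, series around the shared core of compound 1, read out in an ADME assay on Huh-7 cells (Homo sapiens) for cytotoxicity; a lower number here means that less compound is tolerated, a higher number that more compound is tolerated:

- compound 1 `CN1CCN(CCCNCc2cn(-c3ccc([N+](=O)[O-])cc3)nc2-c2ccc(Cl)cc2)CC1` gives 3700 nM
- compound 2 `CN1CCN(CCCNCc2cn(-c3ccc(C(F)(F)F)cc3)nc2-c2ccc(Cl)cc2)CC1` gives 2500 nM
- compound 3 `COC(=O)c1ccc(-c2nn(-c3ccc(F)cc3F)cc2CNCCN2CCN(C)CC2)cc1` gives a limit of the assay, > 20000 nM

Among the two numbers, compound 1 holds the higher one, though the step of a 1.5-fold lower number from compound 1 to compound 2 (0.17 log units; within the scatter) is within the scatter, so compound 1 and compound 2 cannot be told apart. The step was trifluoromethyl in place of nitro on an aromatic carbon. Going by the values given here, compound 3 sits at the limit of > 20000 nM in this assay, at which 1 of the 3 values shown sits, and differs from compound 1 in several places at once, so it gives no single step.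

The next compound, compound 4 `CN1CCN(CCNCc2cn(-c3ccc([N+](=O)[O-])cc3)nc2-c2ccc(Cl)cc2)CC1`, changes the chain instead: 4-methylpiperazin-1-yl in place of (4-methylpiperazin-1-yl)methyl on a saturated chain carbon, two bonds along the chain from an amine nitrogen; read one bond further out, the same difference is 3-(4-methylpiperazin-1-yl)propyl to 2-(4-methylpiperazin-1-yl)ethyl. Among the compounds with values here, no measured step touches this chain, and the one measured step, a 1.5-fold lower number from compound 1 to compound 2 (0.17 log units; within the scatter), was within the scatter. Nothing therefore argues for a step beyond the scatter in either direction. Compound 4 is expected near 3700 nM, estimated between 1500 nM and 9000 nM, that is a step of no change at the digits printed from compound 1 to compound 4 (within the scatter).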

Compound 4, half-maximal cytotoxic concentration: 5000 nM
The estimate for compound 4 lay 1.4-fold (0.13 log units) below the measured number; the measured number falls inside the stated range.
By their numbers in this assay, from the lowest: compounds 2, 1 and 4 (each within the scatter of the next). At a limit, above all of these: compound 3.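

Going by these compounds alone, replacing 3-(4-methylpiperazin-1-yl)propyl with 2-(4-methylpiperazin-1-yl)ethyl gives the first reading at this chain in this assay: a 1.4-fold higher number from compound 1 to compound 4 (0.13 log units; within the scatter). At this position, the change therefore leaves compound 4 indistinguishable from compound 1, so the 2-(4-methylpiperazin-1-yl)ethyl and 3-(4-methylpiperazin-1-yl)propyl chains cannot be told apart here. Nothing measured here gives a cause for this step.

As far as these compounds go, it remains open whether a longer chain, or a morpholine in place of the 4-methylpiperazin-1-yl, would give a step beyond the scatter. Compound 3 gives > 20000 nM, which is a limit of the assay, and as it differs from compound 1 in several places, that limit cannot be tied to any single change.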